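This account rests on a few compounds, and the source may have more. Where it says the series, first, only, none or still open, it means among the compounds named here.

Working notes on the series.

Compound 3 `Cn1cncc1CN1CC(N(CC2CCN(C(=O)C3CCCC3)CC2)S(=O)(=O)c2ccccn2)Cc2cc(C#N)ccc21` stands level with compound 1 `Cn1cncc1CN1CC(N(CC2CCN(C(=O)CNC(=O)OC(C)(C)C)CC2)S(=O)(=O)c2ccccn2)Cc2cc(C#N)ccc21` and compound 2 `Cn1cncc1CN1CC(N(CC2CCN(C(=O)c3ccco3)CC2)S(=O)(=O)c2ccccn2)Cc2cc(C#N)ccc21`: in an ADME assay on Caco-2 cells (Homo sapiens) for permeability, in the apical to basolateral direction (on this read-out lower numbers stand for lower permeability and higher numbers for higher permeability), compound 3 gives 0.5 10^-6 cm/s, compound 1 gives 0.5 10^-6 cm/s and compound 2 gives 0.5 10^-6 cm/s. The three steps among them, no change at the digits printed from compound 1 to compound 2 (within the scatter), no change at the digits printed from compound 1 to compound 3 (within the scatter) and no change at the digits printed from compound 2 to compound 3 (within the scatter), all exchange the group on a carbonyl carbon and none moves the read-out beyond the scatter.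

Compound 4 `Cn1cncc1CN1CC(N(CC2CCN(S(=O)(=O)c3ccccc3)CC2)S(=O)(=O)c2ccccn2)Cc2cc(C#N)ccc21` is the next member: phenylsulfonyl in place of cyclopentylcarbonyl on an amine nitrogen in a ring. The measured steps bear on this only indirectly, since each of them kept the carbonyl in place and varied what sits on it, whereas here the whole cyclopentylcarbonyl group leaves and phenylsulfonyl enters. Going by these compounds, what the series shows is that three different groups at this part of the molecule left the read-out in this assay unchanged, so no step beyond the scatter is expected here either, in either direction; the chance of a shift stays open, as nothing measured tests a sulfonyl at this position.

Compound 4 is expected to give 0.5 10^-6 cm/s, within 0.2 10^-6 cm/s to 1.5 10^-6 cm/s. The step of no change at the digits printed from compound 3 to compound 4 (within the scatter) is thus estimated to stay within the scatter.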

Compound 4, apparent permeability: 0.1 10^-6 cm/s
For compound 4 the middle estimate is 5.0-fold (0.70 log units) above the measured one; the measured number lies below the stated range.
By their numbers in this assay, from the lowest: compound 4; then compounds 1, 2 and 3 (each within the scatter of the next).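

The amine nitrogen in the ring is not a position where any group leaves the read-out in this assay unchanged: the three carbonyl-linked groups stood level, but phenylsulfonyl breaks from them, with a 5.0-fold lower number from compound 3 to compound 4 (0.70 log units; beyond the scatter), a 5.0-fold lower number from compound 2 to compound 4 (0.70 log units; beyond the scatter) and a 5.0-fold lower number from compound 1 to compound 4 (0.70 log units; beyond the scatter). The furan-2-yl of compound 2 shows that an aromatic ring on the carbonyl does not by itself go with a lower number, so among these compounds the drop is seen only with the phenylsulfonyl group. Nothing available gives a reason for this step.

Whether the sulfonyl link or its phenyl ring goes with the drop stays open, as the shown compounds change both at once. A methylsulfonyl group or a benzoyl group on the same nitrogen would separate the two.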